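Compound 3: ethoxy in place of trifluoromethyl

The source may hold more compounds than are shown below. What is called first, only, known or untested is meant among the compounds shown, and "the series" means these compounds.

Measured in a physicochemical assay for solubility, in phosphate buffer, with a stated time of 2 h, at pH 7.4; a higher number here means a more soluble compound, a lower number a less soluble compound:
compound 1 `COc1ccc(-c2nc(Nc3ccc(Cl)cn3)sc2Cl)nc1`: < 10000 nM (a limit)
compound 2 `FC(F)(F)c1ccc(-c2nc(Nc3ccc(Cl)cn3)sc2Cl)nc1`: < 10000 nM (a limit)

Compound 2 has no number, only the limit < 10000 nM. The measured compounds offer no readable value, with the limit of < 10000 nM in this assay, at which 2 of the 2 values shown sit.

Compound 3 `CCOc1ccc(-c2nc(Nc3ccc(Cl)cn3)sc2Cl)nc1` is the next entry, and the change from compound 2 is ethoxy in place of trifluoromethyl on an aromatic carbon. Among the compounds with values here, the one measured step bearing on this is a step that the two limits leave unreadable from compound 1 to compound 2, made on the same aromatic carbon. No size can be carried over from it, so no direction is expected in this assay, and another limit is the likeliest report. The expected step is a step that the limit leaves unreadable from compound 2 to compound 3, an estimate with little behind it. For compound 3 the estimated value is 5000 nM, with an expected range of 1500 nM to 10000 nM.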

Compound 3, solubility: < 10000 nM
Compound 3: only a limit was reported; the forecaster's own chance of this, stated with the estimate: 85%; the middle value is on the limit's open side.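

The steps among compound 1, compound 2 and compound 3 cannot be read in this assay, as all three carry only a limit: the limit of < 10000 nM in this assay, at which 3 of the 3 values shown sit.

Going by these compounds, whether methoxy, trifluoromethyl and ethoxy on this aromatic carbon differ at all in this assay stays open, in both direction and size.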